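The source may hold more compounds than are shown below. What is called first, only, known or untested is meant among the compounds shown, and "the series" means these compounds.

Measured so far:
compound 1, `COc1cccc(C(=O)Oc2ccc3c(=O)c(-c4cc(OC)c(OC)cc4OC)coc3c2)c1`: > 10000 nM
compound 2, `COc1cc(OC)c(-c2coc3cc(OCc4ccccc4Cl)ccc3c2=O)cc1OC`: 4180 nM

In a functional assay on B16 cells (Mus musculus) for antiproliferative activity, read by MTT assay, with a stated time of 24 h (a lower number here means a stronger inhibitor, a higher number a weaker inhibitor), compound 1 gives only a limit, > 10000 nM, so where it stands on the numbers shown is a bound and not a value; the relevant observation is the limit of > 10000 nM in this assay, at which 1 of the 2 values shown sits. Compound 2 carries 2-chlorobenzyl where compound 1 carries (3-methoxyphenyl)carbonyl on the oxygen on the aromatic ring, and that single change gives an at least 2.3-fold lower number from compound 1 to compound 2 (0.37 log units; beyond the scatter).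

The unmeasured compound 3 is `COc1cc(OC)c(-c2coc3cc(OCc4ccccc4Br)ccc3c2=O)cc1OC`. Its difference from compound 1: 2-bromobenzyl in place of (3-methoxyphenyl)carbonyl on an oxygen on an aromatic ring. For the measured compounds named here, the one measured step bearing on this change is an at least 2.3-fold lower number from compound 1 to compound 2 (0.37 log units; beyond the scatter), in which the same (3-methoxyphenyl)carbonyl left and 2-chlorobenzyl entered at the same oxygen. 2-bromobenzyl is the closest neighbour of 2-chlorobenzyl among the groups here, so a downward step in this assay of about the same size, beyond the scatter, is expected, landing near compound 2. The step this estimate implies is an at least 2.5-fold lower number from compound 1 to compound 3 (0.39 log units; beyond the scatter). Compound 3 is therefore estimated at 4000 nM, within a range of 1500 nM to 11000 nM.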

Compound 3, half-maximal inhibitory concentration: 8900 nM
The estimate for compound 3 lay 2.2-fold (0.35 log units) below the measured number, and the stated range covers the measured number.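

In this assay, for the compounds shown here, the halogen on the benzyl group matters at this oxygen on an aromatic ring: bromo in place of chloro on an aromatic carbon gives a 2.1-fold higher number from compound 2 to compound 3 (0.33 log units; beyond the scatter), the first step here between two exact values. The 2-chlorobenzyl result therefore does not carry over unchanged to its closest neighbour, and replacing (3-methoxyphenyl)carbonyl with 2-bromobenzyl gives only an at least 1.1-fold lower number from compound 1 to compound 3 (0.05 log units; that floor lies within the scatter), so a real drop from compound 1 to compound 3 is not established. Compound 1 gives only a limit, so each step from it is a floor and not a measured size: the limit of > 10000 nM in this assay, at which 1 of the 3 values shown sits.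

The compounds shown leave open whether the difference between chloro and bromo reflects a trend across the halogens, which 2-fluorobenzyl and unsubstituted benzyl on the same oxygen would help to test. They also leave open whether the placing of the halogen on the benzyl ring matters, as a comparison of 3-chlorobenzyl or 4-chlorobenzyl with 2-chlorobenzyl would show, and whether a non-halogen group such as 2-methylbenzyl would fit the same picture.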